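A few compounds are considered here, and "the series" means these few. Any claim that something is new, unique, unknown or untested is made for them only; others in the source may bear on it.

Measured compounds in a functional assay on DU-145 cells (Homo sapiens) for inhibition, read by trypan blue exclusion, with a stated time of 72 h; a higher number here means a weaker inhibitor, a lower number a stronger inhibitor:

compound 1 `Cn1c(=O)c(S(=O)(=O)c2ccc(F)cc2F)cc2cnc(Nc3ccc4[nH]c(C(=O)O)cc4c3)nc21`: 10000 nM
compound 2 `Cn1c(=O)c(S(=O)(=O)c2ccc(Cl)cc2Cl)cc2cnc(Nc3ccc4[nH]ccc4c3)nc21`: 1000 nM
compound 3 `Cn1c(=O)c(S(=O)(=O)Nc2ccc(F)cc2)cc2cnc(Nc3ccc4[nH]ccc4c3)nc21`: 5000 nM

Compound 1 stands highest of the three numbers in this assay. Its nearest neighbour is compound 3, whose value lies within the scatter of it; compound 2 sits a clearly lower number, beyond the scatter. For the measured compounds named here, the only step between single-point neighbours is a 5.0-fold higher number from compound 2 to compound 3 (0.70 log units; beyond the scatter), which concerns the group on the sulfonyl sulfur and not the part changed here.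

Compound 4 `Cn1c(=O)c(S(=O)(=O)c2ccc(F)cc2F)cc2cnc(Nc3ccc4cc[nH]c4c3)nc21` differs from compound 1 in 1H-indol-6-yl in place of 2-carboxy-1H-indol-5-yl on a nitrogen on an aromatic ring. Going by the values given here, no measured pair isolates this change: compound 1 against compound 2 and against compound 3 mixes the indole change with a change on the sulfonyl sulfur, so those pairs show only that the two compounds without the carboxy group give the lower numbers. Among the compounds with values here, no step directly bears on the indole change, so the expectation for compound 4 rests on that loose comparison and carries a wide range.

Compound 4 is expected to come in with a lower number than compound 1, with the step estimated as a 4.0-fold lower number from compound 1 to compound 4 (0.60 log units; beyond the scatter). The estimate for compound 4 in this assay is 2500 nM, within a range of 600 nM to 10000 nM.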

Compound 4, half-maximal inhibitory concentration: 5000 nM
Compound 4: the middle estimate sits 2.0-fold (0.30 log units) below what was measured, and the stated range covers the measured number.
By their numbers in this assay, from the lowest: compound 2; then compounds 3, 4 and 1 (each within the scatter of the next).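

In this assay, for the compounds shown here, the exchange of 2-carboxy-1H-indol-5-yl for 1H-indol-6-yl on the nitrogen gives a 2.0-fold lower number from compound 1 to compound 4 (0.30 log units; within the scatter) with the group on the sulfonyl sulfur the same in both compounds, so this is the first reading of this position alone, and the number does not move beyond the scatter. The step carries two changes at once, the loss of the carboxy group and the shift of the attachment from the 5-yl to the 6-yl form of the indole, and on this one pair neither can be read separately, nor can it be said whether the two offset each other. Nothing at hand gives a reason for this result.

The compounds shown leave open how the two parts of the exchange act on their own, which a 1H-indol-5-yl or a 2-carboxy-1H-indol-6-yl partner of compound 1 would separate. They also leave open whether a methyl ester, a primary amide or an aminomethyl group in place of the carboxylic acid on the indole would shift the number, and whether the reading holds with another group on the sulfonyl sulfur.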